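Ethoxy for fluoro in the bromoacrylamide series

The source may report more compounds than this note shows. Statements on the series, on what has been measured and on what is new or still open speak of the compounds shown alone.

In a functional assay on HeLa cells (Homo sapiens) for antiproliferative activity, with a stated time of 48 h (on this read-out lower numbers stand for stronger inhibition and higher numbers for weaker inhibition), compound 1 (`C=C(Br)C(=O)Nc1ccc(/C=C/C(=O)c2ccc(F)cc2)cc1`) gives 1400 nM, level with compound 2 (`C=C(Br)C(=O)Nc1ccc(/C=C/C(=O)c2ccc(OC)cc2)cc1`) at 1400 nM. Compound 3 (`C=C(Br)C(=O)Nc1ccc(/C=C/C(=O)c2cc(OC)c(OC)c(OC)c2)cc1`), which carries further methoxy groups, gives 1100 nM, and this too lies within the scatter of compound 1. The three measured compounds therefore cannot be separated on this read-out.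

The next compound is compound 4 (`C=C(Br)C(=O)Nc1ccc(/C=C/C(=O)c2ccc(OCC)cc2)cc1`). The change is ethoxy in place of fluoro on an aromatic carbon, para to a large group, with the rest of the core of compound 1 kept.

For the measured compounds named here, no ethoxy compound has been measured yet. Going by the values given here, the closest evidence is the single one-place step, no change at the digits printed from compound 1 to compound 2 (within the scatter), which swaps fluoro for methoxy at the same carbon and shows no movement. The value of compound 3 at 1100 nM adds only that more methoxy substitution has so far stayed within the same narrow band. On these data alone, three compounds are a thin basis, so the extra carbon of ethoxy remains untested.

No shift beyond the scatter is expected in this assay, in either direction. The expected step is a 1.1-fold lower number from compound 1 to compound 4 (0.03 log units; within the scatter). Compound 4 is estimated at 1300 nM, with an expected range of 700 nM to 2400 nM.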

Compound 4, half-maximal inhibitory concentration: 750 nM
The estimate for compound 4 lay 1.7-fold (0.24 log units) above the measured number; measured number inside the range.
By their numbers in this assay, from the lowest: compounds 4, 3, 1 and 2 (each within the scatter of the next).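

In this assay, ethoxy on this aromatic carbon, para to a large group, gives a 1.9-fold lower number from compound 1 to compound 4 (0.27 log units; within the scatter), so 3 heavy atoms in place of the single fluorine still leave the read-out inside the scatter. Methyl in place of hydrogen on the saturated chain carbon bound to the oxygen gives a 1.9-fold lower number from compound 2 to compound 4 (0.27 log units; within the scatter), the first reading on the chain at this oxygen, and it too does not separate the two compounds. No measurement shown here bears on the reason for either step.

On these data alone, all four compounds remain inseparable in this assay, so it stays open whether a longer chain such as butoxy, or an amine or a carboxylic acid on this carbon, would move the number beyond the scatter. As far as these compounds go, the bromo group on the acrylamide is the same in all four compounds, so what hydrogen or chloro would do in its place is also open.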